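Methoxy for Methyl on the Anilino Ring of Compound 2

The source may report more compounds than this note shows. Statements on the series, on what has been measured and on what is new or still open speak of the compounds shown alone.

Among the measured compounds shown here, compound 2 `Cc1ccccc1Nc1nnc(Nc2nc(-c3ccc([N+](=O)[O-])cc3)cs2)s1` gives 100 mg/kg in a functional assay on the whole organism (strain albino) with Mus musculus as the target, in the maximal electroshock model, with a stated time of 4 h (on this read-out lower numbers stand for an effect already at smaller amounts and higher numbers for an effect only at larger amounts of compound), the lowest of the two numbers so far; its nearest neighbour, compound 1 `Cc1ccccc1Nc1nnc(Nc2nc(-c3ccc(Cl)cc3)cs2)s1`, gives 300 mg/kg. For the measured compounds named here, the only measured step, a 3.0-fold lower number from compound 1 to compound 2 (0.48 log units; beyond the scatter), concerns a different ring and does not bear on the change to compound 3 `COc1ccccc1Nc1nnc(Nc2nc(-c3ccc([N+](=O)[O-])cc3)cs2)s1`, which is methoxy in place of methyl on an aromatic carbon. Going by the values given here, with no comparable step to lean on, compound 3 is expected to show no step beyond the scatter, no change at the digits printed from compound 2 to compound 3 (within the scatter), and its estimated value is 100 mg/kg, ranging from 50 mg/kg to 300 mg/kg.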

Compound 3, minimum effective dose: 300 mg/kg
The estimate for compound 3 lay 3.0-fold (0.48 log units) below the measured number, within the range that was stated.
By their numbers in this assay, from the lowest: compound 2; then compounds 1 and 3 (each within the scatter of the next).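

Methoxy in place of methyl gives a 3.0-fold higher number from compound 2 to compound 3 (0.48 log units; beyond the scatter) in this assay, the first sign that the read-out responds to a change on this ring, as the earlier step concerned only the other aryl group. Here the 2-methylphenyl group of compound 2 is the better of the two, with the 2-methoxyphenyl group of compound 3 needing a larger dose. No available evidence accounts for this step. The compounds shown leave open how an ethyl group, a fluoro group or plain hydrogen would read at this place, and whether methoxy in place of methyl would give a similar step with the chloro group of compound 1 on the other ring.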